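Aryl group exchange from compound 3 to compound 4

This account rests on a few compounds, and the source may have more. Where it says the series, first, only, none or still open, it means among the compounds named here.

In a functional assay on HL-60 cells (Homo sapiens) for antiproliferative activity, read by MTT assay, with a stated time of 72 h (on this read-out lower numbers stand for stronger inhibition and higher numbers for weaker inhibition), compound 1 (`NC1=NC2(CCOCC2)N(OCCCOc2ccccc2)C(N)=N1`) gives 2460 nM, compound 2 (`NC1=NC2(CCOCC2)N(OCCCOc2ccc(F)cc2)C(N)=N1`) gives 2380 nM and compound 3 (`NC1=NC2(CCOCC2)N(OCCCOc2cc(Cl)c(Cl)cc2Cl)C(N)=N1`) gives 2360 nM. Compound 3 thus stands within the scatter of both others. The change to compound 4 (`NC1=NC2(CCOCC2)N(OCCCOc2cccc(Br)c2)C(N)=N1`) is 3-bromophenyl in place of 2,4,5-trichlorophenyl on an oxygen on a saturated carbon. For the measured compounds named here, three measured steps bear on it: a 1.0-fold lower number from compound 1 to compound 2 (0.01 log units; within the scatter), a 1.0-fold lower number from compound 1 to compound 3 (0.02 log units; within the scatter) and a 1.0-fold lower number from compound 2 to compound 3 (0.00 log units; within the scatter). Each lies within the scatter, so the aryl changes among these three compounds have shown no measurable effect. Going by the values given here, no compound carrying bromine has been measured yet, so this remains an extrapolation. No step beyond the scatter is expected in this assay. The expected step is a 1.0-fold higher number from compound 3 to compound 4 (0.01 log units; within the scatter). Compound 4 is estimated at 2400 nM, with an expected range of 1300 nM to 4500 nM.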

Compound 4, half-maximal inhibitory concentration: 560 nM
For compound 4 the middle estimate is 4.3-fold (0.63 log units) above the measured one, outside the stated range (below it).
By their numbers in this assay, from the lowest: compound 4; then compounds 3, 2 and 1 (each within the scatter of the next).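

The aryl group on an oxygen on a saturated carbon can move this read-out after all: 3-bromophenyl brings a 4.2-fold lower number from compound 3 to compound 4 (0.62 log units; beyond the scatter), a 4.3-fold lower number from compound 2 to compound 4 (0.63 log units; beyond the scatter) and a 4.4-fold lower number from compound 1 to compound 4 (0.64 log units; beyond the scatter). Halogen alone does not give this gain across the series, as compound 2 and compound 3 both carry halogen and stay within the scatter of compound 1. No evidence on hand explains the step.

Still open, as far as these compounds go, is whether the gain follows bromine itself or its place on the ring, which 4-bromophenyl and 3-chlorophenyl would separate. Also open, from the compounds shown here alone, is whether a longer chain keeps it.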